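The source may hold more compounds than are shown below. What is called first, only, known or untested is meant among the compounds shown, and "the series" means these compounds.

Compound 1 `CCCCSc1cc2[nH]c(C3CCCCC3)nc2cc1NC(=O)c1ccc(F)cc1F` carries a butylsulfanyl group on the shared core. In an ADME assay on Vero cells (Chlorocebus sabaeus) for cytotoxicity, read by MTT assay, with a stated time of 2 days (on this read-out lower numbers stand for stronger inhibition and higher numbers for weaker inhibition), compound 1 gives only a limit of the assay, > 200000 nM, so where compound 1 stands is known only as that limit, (the limit of > 200000 nM in this assay, at which 1 of the 3 values shown sits). Two measured relatives carry a 4-fluorophenoxy group in its place: compound 2 `Cc1ccc(C(=O)Nc2cc3nc(C4CCCCC4)[nH]c3cc2Oc2ccc(F)cc2)cc1` and compound 3 `COc1ccc(C(=O)Nc2cc3nc(C4CCCCC4)[nH]c3cc2Oc2ccc(F)cc2)cc1`. In this assay compound 2 gives 26000 nM. In this assay compound 3 gives 40000 nM. Within the data shown here, the single measured step, a 1.5-fold higher number from compound 2 to compound 3 (0.19 log units; within the scatter), alters the aryl amide and leaves the 4-fluorophenoxy group untouched, so it does not bear on the change examined here; it only shows that the two 4-fluorophenoxy compounds sit close to each other. Compound 4 `O=C(Nc1cc2nc(C3CCCCC3)[nH]c2cc1Oc1ccc(F)cc1)c1ccc(F)cc1F` has not yet been measured; it differs from compound 1 by 4-fluorophenoxy in place of butylsulfanyl on an aromatic carbon. It therefore carries the same 4-fluorophenoxy group as compound 2 and compound 3. Because compound 2 gives 26000 nM and compound 3 gives 40000 nM, compound 4 is expected to return a number rather than a limit. The expected step is an at least 5.7-fold lower number from compound 1 to compound 4 (0.75 log units; beyond the scatter), toward a lower number. Compound 4 is estimated at 35000 nM, within a range of 12000 nM to 120000 nM.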

Compound 4, half-maximal inhibitory concentration: > 200000 nM
Compound 4: no number, only a limit; the forecaster's own chance of this, stated with the estimate: 20%; middle value at least 5.7-fold (0.75 log units) away from the limit.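

In this assay compound 4 gives > 200000 nM, which is a limit, and it joins compound 1 there: the limit of > 200000 nM in this assay, at which 2 of the 4 values shown sit. The change from butylsulfanyl to 4-fluorophenoxy on this aromatic carbon therefore cannot be read as a step, and the 4-fluorophenoxy group alone does not bring a number on this read-out, which compound 2 and compound 3 could not show. With the 4-fluorophenoxy group held fixed, the group on the carbonyl carbon separates the compounds: 2,4-difluorophenyl in place of 4-methoxyphenyl gives an at least 5.0-fold higher number from compound 3 to compound 4 (0.69 log units; beyond the scatter), and 2,4-difluorophenyl in place of 4-methylphenyl gives an at least 7.6-fold higher number from compound 2 to compound 4 (0.88 log units; beyond the scatter).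

The compounds shown leave open how butylsulfanyl behaves with 4-methylphenyl or 4-methoxyphenyl on the carbonyl carbon, a pairing that could turn the change at this position into a readable step. They also leave open whether any other group at this position, such as an amine or a carboxylic acid, would return a number alongside 2,4-difluorophenyl.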